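The source may hold more compounds than are shown below. What is called first, only, known or untested is meant among the compounds shown, and "the series" means these compounds.

Measured so far in an assay on isolated protein (Mus musculus) for inhibition of IL15-IL15 receptor (Homo sapiens), read by resazurin assay, with stated times of 30 min and 2.5 days; on this read-out higher numbers stand for weaker inhibition and lower numbers for stronger inhibition:

Compound 1 `Cn1c(Cc2nn(C)c(=O)c3ccccc23)nnc1SCCCCCCCCCCC(=O)Nc1ccccc1Cl` — 15000 nM

Compound 2 `Cn1c(Cc2nn(C)c(=O)c3ccccc23)nnc1SCCCCCCCC(=O)Nc1ccc(O)cc1` — a limit of the assay, > 30000 nM

Compound 3 `Cn1c(Cc2nn(C)c(=O)c3ccccc23)nnc1SCCCCCCCC(=O)Nc1ccccc1O` — 27000 nM

Compound 3 stands at the highest of the two numbers given in this assay; the nearest, compound 1, is within the scatter of it. Compound 2 gives only a limit, (the limit of > 30000 nM in this assay, at which 1 of the 3 values shown sits), and no number. Among the measured compounds shown here, the one step measured in one place, an at least 1.1-fold lower number from compound 2 to compound 3 (0.04 log units; that floor lies within the scatter), moved the hydroxyl on the amide-type nitrogen's aryl group and stayed within the scatter.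

Compound 4 `CCCCCCCCCCSc1nnc(Cc2nn(C)c(=O)c3ccccc23)n1C` differs from compound 3 by propyl in place of (2-hydroxyphenyl)carbamoyl on a saturated chain carbon, seven bonds along the chain from a sulfur. For the measured compounds named here, no measured step removes the carbamoyl unit or the aryl group as a whole; the only measured step touched the hydroxyl position and changed little. With all three measured values lying at the weak end of this assay, and nothing in the measured steps pointing toward stronger inhibition, compound 4 is expected to stay at that weak end, with a step of a 1.1-fold higher number from compound 3 to compound 4 (0.05 log units; within the scatter) or none beyond the scatter. The estimate for compound 4 in this assay is 30000 nM, between 12000 nM and 70000 nM, with a fair chance that only a limit is reported.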

Compound 4, half-maximal inhibitory concentration: 7600 nM
Compound 4: middle estimate off by 3.9-fold (0.60 log units), on the high side, and the stated range ends above it.
By their numbers in this assay, from the lowest: compounds 4, 1 and 3 (each within the scatter of the next, the first and the last beyond it). At a limit, above all of these: compound 2.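

In this assay, the results now include replacement of a whole aryl carbamoyl unit at this chain position, and the change goes toward stronger inhibition: propyl in place of (2-hydroxyphenyl)carbamoyl gives a 3.6-fold lower number from compound 3 to compound 4 (0.55 log units; beyond the scatter). Propyl in place of (4-hydroxyphenyl)carbamoyl gives an at least 3.9-fold lower number from compound 2 to compound 4 (0.59 log units; beyond the scatter), a step that rests on a limit for compound 2 and not on a number: the limit of > 30000 nM in this assay, at which 1 of the 4 values shown sits. Hydrogen in place of (2-chlorophenyl)carbamoyl, on a saturated chain carbon, gives a 2.0-fold lower number from compound 1 to compound 4 (0.30 log units; within the scatter), which stays within the scatter, so across these three pairs no aryl carbamoyl compound shows stronger inhibition than the compound without that unit.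

The compounds shown leave open whether an amine or a carboxylic acid in place of propyl at this chain carbon would keep the number of compound 4 at 7600 nM. They also leave open whether a longer or a shorter plain alkyl chain would move that number, and whether a simple carboxamide, without the aromatic ring, would behave like propyl or like the aryl carbamoyl groups.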